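This account rests on a few compounds, and the source may have more. Where it says the series, first, only, none or still open, it means among the compounds named here.

Compound 1 `O=C(CSC(=S)N[C@H]1CCOC1=O)Nc1ccccc1F`: in a functional assay on SMMC-7721 cells (Homo sapiens) for cytotoxicity, read by MTT assay, with a stated time of 72 h (on this read-out higher numbers stand for weaker inhibition and lower numbers for stronger inhibition), compound 1 reaches only the assay limit > 128000 nM.
Compound 2 `O=C(CSC(=S)N[C@H]1CCOC1=O)Nc1ccc(Cl)cc1`: in this assay compound 2 reaches only the assay limit > 128000 nM.
Compound 3 `Cc1cccc(NC(=O)CSC(=S)N[C@H]2CCOC2=O)c1`: in this assay compound 3 reaches only the assay limit > 128000 nM.

Compound 3 stands nowhere distinct among these numbers. For it, as for the other two, this assay returns a limit rather than a measured number, and that limit is the point at which every value shown sits (the limit of > 128000 nM in this assay, at which 3 of the 3 values shown sit). The steps a step that the two limits leave unreadable from compound 1 to compound 2, a step that the two limits leave unreadable from compound 1 to compound 3 and a step that the two limits leave unreadable from compound 2 to compound 3 therefore have no readable size: two limits cannot be set against each other.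

Compound 4 `O=C(CSC(=S)N[C@H]1CCOC1=O)Nc1cccc(Cl)c1` differs from compound 3 by a single change, (chloro in place of methyl on an aromatic carbon), chloro in place of methyl on an aromatic carbon, meta to a large group. The nearest measured comparison, the exchange of a chlorophenyl for a methylphenyl in a step that the two limits leave unreadable from compound 2 to compound 3, puts the chloro in a different place and has no readable size either, so it gives no direction for the present change. Among the compounds with values here, with three limits and no measured step to build on, no step beyond the scatter can be expected in this assay. The expected step that the limit leaves unreadable from compound 3 to compound 4 is accordingly none beyond the scatter. Compound 4 is expected to give 200000 nM, in a range from 40000 nM to 1000000 nM, most likely again as a limit.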

Compound 4, half-maximal inhibitory concentration: > 128000 nM
Compound 4: no number, only a limit (the forecaster's own chance of this, stated with the estimate: 85%); the middle value does not contradict the limit.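

In this assay compound 4 gives only a limit, > 128000 nM. No step from compound 1, compound 2 or compound 3 to compound 4 can be read, because all four compounds share one limit: the limit of > 128000 nM in this assay, at which 4 of the 4 values shown sit.

From the compounds shown here alone, whether exchanging these phenyl groups changes cytotoxicity at all stays open, as compound 1, compound 2, compound 3 and compound 4 give no measured number.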